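This account rests on a few compounds, and the source may have more. Where it says the series, first, only, none or still open, it means among the compounds named here.

Measured so far in a functional assay on HT-29 cells (Homo sapiens) for inhibition, read by MTT assay, with a stated time of 72 h; a higher number here means a weaker inhibitor of growth, a lower number a stronger inhibitor of growth:
compound 1, `O=S(=O)(NCCCCNCc1ccc(Br)cc1)c1cc(C(F)(F)F)cc(C(F)(F)F)c1`, 1600 nM
compound 2, `COc1ccc(CNCCCNS(=O)(=O)c2cc(C(F)(F)F)cc(C(F)(F)F)c2)cc1OC`, 2700 nM
compound 3, `COc1cccc(CNCCCNS(=O)(=O)c2cc(C(F)(F)F)cc(C(F)(F)F)c2)c1`, 10000 nM

Compound 3 carries the highest number of the three. Its nearest neighbour is compound 2, the step being a 3.7-fold higher number from compound 2 to compound 3 (0.57 log units; beyond the scatter); the furthest is compound 1, with a 6.3-fold higher number from compound 1 to compound 3 (0.80 log units; beyond the scatter). Both steps lie beyond the scatter, so compound 3 is the weakest inhibitor of growth among the measured compounds.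

Compound 4, `CN(CCCNS(=O)(=O)c1cc(C(F)(F)F)cc(C(F)(F)F)c1)Cc1ccccc1`, is not yet measured. Its difference from compound 3 is benzyl(methyl)amino in place of (3-methoxybenzyl)amino on a saturated chain carbon, three bonds along the chain from a sulfonamide nitrogen.

For the measured compounds named here, no measured step matches this change directly. Going by the values given here, the step from compound 2 to compound 3 is the closest precedent: removal of one methoxy on the aromatic carbon raised the number, and compound 4 removes the remaining methoxy. The change from compound 1 to compound 3 shows that exchanging the benzylamino group itself can move the number by a similar or larger amount. On these data alone, whether the methyl on the amine nitrogen offsets or adds to this is unknown. Taken together, a modest further rise in this assay is expected, with a wide range.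

Compound 4 is estimated at 16000 nM, between 5000 nM and 50000 nM, an expected step of a 1.6-fold higher number from compound 3 to compound 4 (0.20 log units; within the scatter).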

Compound 4, concentration for 50% growth inhibition: > 50000 nM
Compound 4: only a limit was reported; the forecaster's own chance of this, stated with the estimate: 25%; at least 3.1-fold (0.49 log units) between middle value and limit.
By their numbers in this assay, from the lowest: compounds 1 and 2 (each within the scatter of the next); then compound 3. At a limit, above all of these: compound 4.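

In this assay compound 4 sits at a limit of the assay (> 50000 nM), which is a limit and not a number: the limit of > 50000 nM in this assay, at which 1 of the 4 values shown sits. Even so, the change from (3-methoxybenzyl)amino to benzyl(methyl)amino, on a saturated chain carbon, three bonds along the chain from a sulfonamide nitrogen, can be read as a floor (an at least 5.0-fold higher number from compound 3 to compound 4 (0.69 log units; beyond the scatter)), and it is the only change shown that ends at the limit. For the compounds shown here, the wider step (an at least 31-fold higher number from compound 1 to compound 4 (1.49 log units; beyond the scatter)) is large where the earlier steps were modest, so those earlier steps understated how far a change at this position can move the number.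

Still open, on these data alone, is which part of the change carries the rise, the lost methoxy or the methyl on the amine nitrogen, as the two change together in compound 4. A plain benzylamino group or a 3-methoxybenzyl(methyl)amino group would separate them, and a nitrile or a carboxylic acid on the benzyl ring, or a longer chain, would show how far this position can be pushed in either direction.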